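Working notes: three measured amides and one to follow

The source may hold more compounds than are shown below. What is called first, only, known or untested is meant among the compounds shown, and "the series" means these compounds.

Measured so far in an in vitro functional assay on CHO-CREluc cells for antagonist activity at growth hormone secretagogue receptor type 1 (Homo sapiens), read by a luciferase reporter, with a stated time of 4 h; a higher number here means a weaker inhibitor, a lower number a stronger inhibitor:
- compound 1 `CN1CCN(CC(=O)NC2(c3ccc(Cl)cc3)C(=O)Nc3cc(Cl)c(Cl)cc32)CC1`: compound 1 reports only a limit, > 10000 nM
- compound 2 `Cc1cc2c(cc1Cl)NC(=O)C2(NC(=O)CN1CCN(C)CC1)c1cccc(Cl)c1`: compound 2 gives 1180 nM
- compound 3 `CCN1CCC(CC(=O)NC2(c3ccc(Cl)c(Cl)c3)C(=O)Nc3cc(Cl)cc(Cl)c32)CC1`: compound 3 gives 1 nM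

The value of compound 1 is a limit of this assay and not a number (the limit of > 10000 nM in this assay, at which 1 of the 3 values shown sits). Of the two numbers, compound 3 stands lowest; the nearest, compound 2, sits a step higher that is beyond the scatter. Among the compounds with values here, the three measured compounds differ from one another in several places at once, so no single-change step is available among them.

Compound 4 `CN(C)C1CCN(CC(=O)NC2(c3ccc(Cl)c(Cl)c3)C(=O)Nc3cc(Cl)cc(Cl)c32)CC1` is not yet measured. Against compound 3 it carries 4-(dimethylamino)piperidin-1-yl in place of 1-ethylpiperidin-4-yl on a saturated chain carbon bound to a carbonyl carbon. The shared core and the amide link of compound 3 are retained; only the group on that chain carbon changes, and the number of nitrogens in it rises.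

With no measured step of this kind in the series, the expectation rests on the retained core and the shape of the group that enters. The step from compound 3 to compound 4 is expected to be small, a 5.0-fold higher number from compound 3 to compound 4 (0.70 log units; beyond the scatter), and may well lie within the scatter. In this assay compound 4 is estimated at 5 nM, with a range from 1 nM to 30 nM.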

Compound 4, half-maximal inhibitory concentration: 239 nM
Compound 4: the middle estimate sits 48-fold (1.68 log units) below what was measured; the measured number lies above the stated range.
By their numbers in this assay, from the lowest: compound 3; then compound 4; then compound 2. At a limit, above all of these: compound 1.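

In this assay the group on the saturated chain carbon bound to a carbonyl carbon has a large effect: with the shared core and the amide link retained, 4-(dimethylamino)piperidin-1-yl in place of 1-ethylpiperidin-4-yl gives a 240-fold higher number from compound 3 to compound 4 (2.38 log units; beyond the scatter) in this series. Within the data shown here, this is the first single-change step available, so this chain position is the only place where the effect of one change can be read. Compound 4 at 239 nM still gives a number and not a limit, so this change weakens inhibition without abolishing it in this assay.

Going by these compounds, how 1-methylpiperidin-4-yl, morpholin-4-yl or a group bearing a carboxylic acid would read at the same chain carbon remains open, as does which difference between the two groups, including the count of nitrogens, carries the step. No measurement shown bears on the reason for the size of this step.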